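A few compounds are considered here, and "the series" means these few. Any claim that something is new, unique, unknown or untested is made for them only; others in the source may bear on it.

Going by the values given here, compound 2 `Cc1cc(S(=O)(=O)/N=C(\N)N/N=C/C#Cc2ccccc2)c(SCc2ccccc2Cl)cc1Cl` stands at the higher of the two numbers so far recorded in a functional assay on HCT-116 cells (Homo sapiens) for antiproliferative activity, read by MTT assay, with a stated time of 72 h (on this read-out higher numbers stand for weaker inhibition and lower numbers for stronger inhibition), where compound 2 gives 27000 nM. Among the compounds with values here, its only neighbour is compound 1 `Cc1cc(S(=O)(=O)/N=C(\N)N/N=C/C#Cc2ccccc2)c(SCc2ccccc2C)cc1Cl`, and in this assay compound 1 gives 19000 nM. Within the data shown here, the single measured step, a 1.4-fold higher number from compound 1 to compound 2 (0.15 log units; within the scatter), exchanges one substituent on an aromatic carbon and leaves the read-out essentially where it was.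

The step to compound 3 `Cc1cc(S(=O)(=O)/N=C(\N)N/N=C/C#Cc2ccccc2)c(SCc2cccc3ccccc23)cc1Cl` is of a different kind: naphthalen-1-yl in place of 2-chlorophenyl on a saturated chain carbon bound to a sulfur. Among the measured compounds shown here, no measured pair in this small set exchanges a single aromatic ring for a fused two-ring system at that place, so the only guidance is indirect. For the measured compounds named here, what is known is that the one change made so far at this benzyl group, a 1.4-fold higher number from compound 1 to compound 2 (0.15 log units; within the scatter), stayed within the scatter, which gives no reason to expect a large movement in either direction.

On that basis compound 3 is expected to sit close to compound 2, with a step of about a 1.2-fold lower number from compound 2 to compound 3 (0.09 log units; within the scatter) that is itself estimated to remain within the scatter. The estimate for compound 3 in this assay is therefore 22000 nM, in a range from 8000 nM to 60000 nM.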

Compound 3, half-maximal inhibitory concentration: 10000 nM
Compound 3: middle estimate off by 2.2-fold (0.34 log units), on the high side; measured number inside the range.
By their numbers in this assay, from the lowest: compounds 3, 1 and 2 (each within the scatter of the next, the first and the last beyond it).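

Going by these compounds alone, at the saturated chain carbon bound to a sulfur, naphthalen-1-yl in place of 2-chlorophenyl is the first change in this assay to move the read-out beyond the scatter, a modest step toward stronger inhibition (a 2.7-fold lower number from compound 2 to compound 3 (0.43 log units; beyond the scatter)). Against compound 1, however, the same fused two-ring group produces no separation from the 2-methylphenyl group (a 1.9-fold lower number from compound 1 to compound 3 (0.28 log units; within the scatter)), so the shift appears only when compound 2 is the reference and compound 3 cannot be ranked above both neighbours. This position therefore accepts naphthalen-1-yl with no loss in this read-out, but nothing at hand explains the step from compound 2.

The compounds shown leave open whether the second fused ring matters in itself, as the only single-ring groups here carry a chloro or a methyl substituent and an unsubstituted phenyl would be needed to separate these contributions. They also leave open how the read-out would respond at this place to naphthalen-2-yl, or to a ring bearing an amine or a carboxylic acid.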